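The source may hold more compounds than are shown below. What is called first, only, known or untested is meant among the compounds shown, and "the series" means these compounds.

Measured compounds:
- compound 1 `COCCOCCOc1cccc2ccc(N)nc12`; in an assay on cells with melanin-concentrating hormone receptor 1 (Homo sapiens) as the target, read by radioligand binding (a higher number here means a weaker inhibitor, a lower number a stronger inhibitor), compound 1 gives only a limit, > 2000 nM
- compound 2 `CC1CCC(Oc2cccc3ccc(N)nc23)C1`; in this assay compound 2 gives 823 nM
- compound 3 `Nc1ccc2cccc(OCC3CCCC3)c2n1`; in this assay compound 3 gives 53 nM

Compound 3 holds the lowest of the two numbers in this assay; the nearest is compound 2, with a 16-fold lower number from compound 2 to compound 3 (1.19 log units; beyond the scatter). The remaining value is a limit: for compound 1 the assay reports (the limit of > 2000 nM in this assay, at which 1 of the 3 values shown sits), so the step is an at least 37-fold lower number from compound 1 to compound 3 (1.57 log units; beyond the scatter).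

Compound 4 `Nc1ccc2cccc(OCC3CCOC3)c2n1` is the next member: oxolan-3-yl in place of cyclopentyl on a saturated chain carbon bound to an oxygen on an aromatic ring.

Both measured steps bear on this change, though neither matches it closely. The step from a cyclopentylmethyl group back to (2-methoxyethoxy)methyl, an at least 37-fold lower number from compound 1 to compound 3 (1.57 log units; beyond the scatter) read in reverse, shows that ether oxygens in the side chain at this position cost a great deal. The step of a 16-fold lower number from compound 2 to compound 3 (1.19 log units; beyond the scatter) shows that the shape of the saturated ring and its link to the aromatic oxygen also matter. Compound 4 keeps the ring and the methylene link of compound 3 and introduces a single ring oxygen, a smaller change than either measured one. A moderate rise in the number is therefore expected for compound 4, well short of the step to compound 1. For compound 4 the step is estimated as a 3.8-fold higher number from compound 3 to compound 4 (0.58 log units; beyond the scatter). Compound 4 is estimated at 200 nM in this assay, within 60 nM to 700 nM.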

Compound 4, half-maximal inhibitory concentration: 115 nM
Compound 4: the middle estimate sits 1.7-fold (0.24 log units) above what was measured; the measured number falls inside the stated range.
By their numbers in this assay, from the lowest: compound 3; then compound 4; then compound 2. At a limit, above all of these: compound 1.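

Replacing cyclopentyl with oxolan-3-yl on the saturated chain carbon gives, in this assay, a 2.2-fold higher number from compound 3 to compound 4 (0.34 log units; beyond the scatter), so at this position one hydrogen-bond acceptor inside the five-membered ring comes at only a modest cost, far less than the open-chain ether of compound 1 might have suggested. The ring with its methylene link also keeps its advantage with the oxygen in place: (oxolan-3-yl)methyl in place of 3-methylcyclopentyl on the aromatic oxygen gives a 7.2-fold lower number from compound 2 to compound 4 (0.85 log units; beyond the scatter). Replacing the open (2-methoxyethoxy)methyl chain with the ring gives an at least 17-fold lower number from compound 1 to compound 4 (1.24 log units; beyond the scatter), and the size of that step rests on a limit, not a number: the limit of > 2000 nM in this assay, at which 1 of the 4 values shown sits.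

Still open, going by these compounds, is whether the position of the ring oxygen matters, as with oxolan-2-yl, and whether a six-membered oxan-4-yl ring, a pyrrolidin-3-yl ring with nitrogen in place of oxygen, or a longer chain to the aromatic oxygen would stay close to compound 4 in this assay. The compounds shown also leave open how a carboxylic acid or a primary amine on the ring would read, and whether the step from cyclopentyl to oxolan-3-yl holds on a changed core.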